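Estimating a Chloropyridinyl Ester from Two Measured Esters

The compounds below may be only part of what the source reports. "The series", "measured", "known", "first", "only" and "open" are said of these compounds alone.

Two esters built on a shared core have been measured so far. In an ADME assay on a cell-free system (plasma, Homo sapiens) for metabolic stability, with Plasma (Rattus norvegicus) as the target, read by HPLC, at pH 7.4 (a higher number here means that the compound lasts longer, a lower number that the compound disappears faster), compound 2 `CC(=O)Oc1ccccc1C(=O)O[C@H]1CO[C@H]2[C@@H]1OC[C@H]2OC(=O)c1cccc(C)c1` gives 0.0203 h, the higher of the two numbers, while compound 1 `CC(=O)Oc1ccccc1C(=O)O[C@H]1CO[C@H]2[C@@H]1OC[C@H]2OC(=O)c1snnc1C` gives 0.0065 h. Among the measured compounds shown here, the only step between measured compounds is a 3.1-fold higher number from compound 1 to compound 2 (0.49 log units; beyond the scatter). Compound 3 `CC(=O)Oc1ccccc1C(=O)O[C@H]1CO[C@H]2[C@@H]1OC[C@H]2OC(=O)c1cnccc1Cl` is the unmeasured member, and its change from compound 2 is 4-chloropyridin-3-yl in place of 3-methylphenyl on a carbonyl carbon. For the measured compounds named here, no measured step covers this exact exchange. Going by the values given here, the one step that exists replaced a ring with hetero atoms by the methylphenyl ring and raised the number, and compound 3 moves back to a ring with a hetero atom, so a decrease beyond the scatter seems more likely than an increase, although the chloropyridinyl group itself has no precedent here. Compound 3 is therefore estimated at 0.01 h, with a range from 0.004 h to 0.025 h. The expected step is a 2.0-fold lower number from compound 2 to compound 3 (0.31 log units; beyond the scatter).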

Compound 3, half-life: 0.0322 h
Compound 3: the middle estimate sits 3.2-fold (0.51 log units) below what was measured; measured number outside the range, above it.
By their numbers in this assay, from the lowest: compound 1; then compounds 2 and 3 (each within the scatter of the next).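

In this assay a ring with a hetero atom on this carbonyl carbon does not by itself bring a shorter half-life: a 1.6-fold higher number from compound 2 to compound 3 (0.20 log units; within the scatter) stays within the scatter, so 4-chloropyridin-3-yl and 3-methylphenyl cannot be told apart here. Compound 1 now stands apart from two different six-membered aromatic rings rather than one, with a 5.0-fold higher number from compound 1 to compound 3 (0.69 log units; beyond the scatter) beyond the scatter, although this holds only for these three compounds. No evidence is available to explain this difference.

Still open, as far as these compounds go, is whether the number holds when the ring carries an amine or a carboxylic acid instead of chlorine or methyl, or when a longer carbon chain replaces the ring on this carbonyl carbon. Also open, from the compounds shown here alone, is whether changes elsewhere on the shared core would shift the number more.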